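The source may report more compounds than this note shows. Statements on the series, on what has been measured and on what is new or still open speak of the compounds shown alone.

Of the compounds shown here, two sharing a core have been tested so far. Compound 1 `CCN1CCc2c(sc(NC=O)c2C(N)=O)C1` gives > 25000 nM in a functional assay (strain AB) with Danio rerio as the target, read by microscopy, with a stated time of 1 h (on this read-out higher numbers stand for an effect only at larger amounts of compound and lower numbers for an effect already at smaller amounts), and that value is a limit, not a number. Among the compounds with values here, compound 2 `NC(=O)c1c(NC(=O)Nc2ccc(Cl)cc2)sc2c1CCN(CC1CCCCC1)C2` gives 1890 nM as the only actual number so far, which leaves it nothing measured to be ranked against. Compound 3 `CC(C)(C)CN1CCc2c(sc(NC(=O)Nc3ccc(Cl)cc3)c2C(N)=O)C1` has tert-butyl in place of cyclohexyl on a saturated chain carbon bound to an amine nitrogen in a ring, a change of tert-butyl in place of cyclohexyl on a saturated chain carbon bound to an amine nitrogen in a ring with the rest of compound 2 kept as it is. Within the data shown here, no step at a single place has been measured yet, so any forecast here is tentative. Both groups are carbon only and carry no net charge. A small step towards higher numbers is expected in this assay and it may stay within the usual scatter. The estimate amounts to an expected step of a 1.5-fold higher number from compound 2 to compound 3 (0.17 log units; within the scatter) on this read-out. For compound 3 the expected value is 2800 nM with an estimated range from 900 nM to 10000 nM as the likely span.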

Compound 3, half-maximal effective concentration: 5560 nM
Estimate against measurement, compound 3: 2.0-fold (0.30 log units) below; the measured number falls inside the stated range.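

Putting tert-butyl in place of cyclohexyl on a saturated chain carbon bound to an amine nitrogen in a ring gives, in this assay, a 2.9-fold higher number from compound 2 to compound 3 (0.47 log units; beyond the scatter). This shows that the read-out responds to this position even when one carbon-only group without net charge replaces another, and that a ring in this group is not needed for a measurable effect, since compound 3, which has no ring there, gives 5560 nM. Compound 1 remains a limit rather than a number, so no step to it can be read: the limit of > 25000 nM in this assay, at which 1 of the 3 values shown sits.

Going by these compounds, whether a methyl group, a longer chain, an amine or a carboxylic acid at this position would move the number further remains open. This single step also cannot separate the loss of the ring from the smaller number of carbons.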